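Swapping a Ring for a Branched Chain on the Oxygen

This account rests on a few compounds, and the source may have more. Where it says the series, first, only, none or still open, it means among the compounds named here.

Within the data shown here, compound 3 `Cc1cc(OC2CCCC2)c(S(C)(=O)=O)cc1C(=O)N=C(N)N` gives 27 nM in a functional assay for inhibition of sodium/hydrogen exchanger (Oryctolagus cuniculus) (a lower number here means a stronger inhibitor, a higher number a weaker inhibitor), the highest of the three numbers measured so far. Compound 1 `CCC(C)c1cc(C)c(C(=O)N=C(N)N)cc1S(C)(=O)=O` gives 8 nM, and compound 2 `Cc1cc(C2CCCCC2)c(S(C)(=O)=O)cc1C(=O)N=C(N)N` gives 22 nM. The step of a 3.4-fold higher number from compound 1 to compound 3 (0.53 log units; beyond the scatter) lies beyond the scatter, whereas a 1.2-fold higher number from compound 2 to compound 3 (0.09 log units; within the scatter) stays within it. Compound 4 `Cc1cc(OC(C)(C)C)c(S(C)(=O)=O)cc1C(=O)N=C(N)N` differs from compound 3 by tert-butyl in place of cyclopentyl on an oxygen on an aromatic ring. Among the measured compounds shown here, no measured step alters the group on the oxygen itself; the two steps that lead to compound 3 exchange groups on an aromatic carbon and were modest at most. A step of a 1.1-fold higher number from compound 3 to compound 4 (0.05 log units; within the scatter) is therefore expected, small enough that it may stay within the scatter in either direction. Compound 4 is estimated at 30 nM, with a range from 12 nM to 75 nM.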

Compound 4, half-maximal inhibitory concentration: 9.4 nM
Compound 4: the middle estimate sits 3.2-fold (0.50 log units) above what was measured, and the stated range ends above it.
By their numbers in this assay, from the lowest: compounds 1 and 4 (each within the scatter of the next); then compounds 2 and 3 (each within the scatter of the next).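

In this assay tert-butyl in place of cyclopentyl gives a 2.9-fold lower number from compound 3 to compound 4 (0.46 log units; beyond the scatter) and so shows that the group on the oxygen is not a silent spot. Tert-butoxy also gives a 2.3-fold lower number from compound 2 to compound 4 (0.37 log units; beyond the scatter) when set against cyclohexyl on the aromatic carbon, while a 1.2-fold higher number from compound 1 to compound 4 (0.07 log units; within the scatter) leaves it level with sec-butyl there. The data at hand offer nothing on what lies behind these steps. Going by these compounds, whether an isopropyl group or a longer chain on the oxygen would keep this level stays open.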